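Working notes: alkyl variation on the double-bonded nitrogen

The compounds below may be only part of what the source reports. "The series", "measured", "known", "first", "only" and "open" are said of these compounds alone.

Measured compounds, with the minimum effective dose in a functional assay on the whole organism (blood, strain Wistar-Okamoto) with Rattus norvegicus as the target, with a stated time of 5 days; on this read-out higher numbers stand for an effect only at larger amounts of compound and lower numbers for an effect already at smaller amounts:
compound 1 `CCCCC/N=C(\NC#N)Nc1cccnc1`, compound 1 gives 20 mg/kg
compound 2 `N#CN/C(=N\C1CCCC1)Nc1cccnc1`, compound 2 gives 20 mg/kg
compound 3 `N#CN/C(=N\C1CCCCC1)Nc1cccnc1`, compound 3 gives 20 mg/kg

Compound 3 stands level with compounds 1 and 2 at the digits shown: no change at the digits printed from compound 1 to compound 3 (within the scatter) and no change at the digits printed from compound 2 to compound 3 (within the scatter) are both within the scatter, as is no change at the digits printed from compound 1 to compound 2 (within the scatter). Compound 4 `CCC(C)(CC)/N=C(\NC#N)Nc1cccnc1` differs from compound 3 by 1-ethyl-1-methylpropyl in place of cyclohexyl on a double-bonded nitrogen. Among the compounds with values here, all three measured steps exchange one alkyl group for another at this same position without change beyond the scatter, and that is the only evidence bearing on the present step; a branched open chain of this kind has not been measured. The expectation is therefore a step of no change at the digits printed from compound 3 to compound 4 (within the scatter) of no size beyond the scatter. Compound 4 is expected to give 20 mg/kg, with a range from 10 mg/kg to 40 mg/kg.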

Compound 4, minimum effective dose: 0.5 mg/kg
Compound 4: the middle estimate sits 40-fold (1.60 log units) above what was measured; measured number outside the range, below it.
By their numbers in this assay, from the lowest: compound 4; then compounds 1, 2 and 3 (each within the scatter of the next).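

In this assay the 1-ethyl-1-methylpropyl group brings a 40-fold lower number from compound 3 to compound 4 (1.60 log units; beyond the scatter) and likewise a 40-fold lower number from compound 2 to compound 4 (1.60 log units; beyond the scatter) and also a 40-fold lower number from compound 1 to compound 4 (1.60 log units; beyond the scatter) so this place on a double-bonded nitrogen does respond to the alkyl group, which compounds 1, 2 and 3 gave no sign of. Cyclohexyl and 1-ethyl-1-methylpropyl carry the same carbon count, so that count alone does not set the read-out between compound 3 and compound 4.

Going by these compounds, whether the low number belongs to this one group stays open: tert-butyl or 1,1-dimethylpropyl at this place would test that. No measurement at hand explains the step.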